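The source may report more compounds than this note shows. Statements on the series, on what has been measured and on what is new or still open speak of the compounds shown alone.

Measured so far in a functional assay (aorta) with Rattus norvegicus as the target; a higher number here means a weaker inhibitor, a lower number a stronger inhibitor:
compound 1 `C=C(c1ccccc1)c1ccc2c(c1)[C@@H](/N=C(\NC#N)Nc1ccc(Cl)cc1)[C@H](O)C(C)(C)O2` gives 10700 nM
compound 2 `CC1(C)Oc2ccc(S(=O)(=O)Nc3ccccc3)cc2[C@@H](/N=C(\NC#N)Nc2ccc(Cl)cc2)[C@@H]1O` gives 3300 nM
compound 3 `CC1(C)Oc2ccc(S(=O)(=O)N3CCC(Cc4ccccc4)CC3)cc2[C@@H](/N=C(\NC#N)Nc2ccc(Cl)cc2)[C@@H]1O` gives only a limit, > 30000 nM

Compound 2 stands lowest of the two numbers shown; the single measured step, a 3.2-fold lower number from compound 1 to compound 2 (0.51 log units; beyond the scatter), leads to it. The result for compound 3 is a limit of this assay and not a number (the limit of > 30000 nM in this assay, at which 1 of the 3 values shown sits). Compound 4 `CC1(C)Oc2ccc(S(=O)(=O)N3CCCC4CCCCC43)cc2[C@@H](/N=C(\NC#N)Nc2ccc(Cl)cc2)[C@@H]1O` differs from compound 2 in one place: a group of 10 heavy atoms (9 carbon, 1 nitrogen; one six-membered non-aromatic ring of carbon only, one six-membered non-aromatic ring with 1 hetero atom) in place of a group of 7 heavy atoms (6 carbon, 1 nitrogen; one six-membered aromatic ring of carbon only), on a sulfonyl sulfur. Among the measured compounds shown here, no measured step covers this change directly. Compound 2 and compound 3 both carry the sulfonyl group on the aromatic carbon, and in compound 3 the anilino group is replaced by a saturated nitrogen ring; compound 4 makes a replacement of the same kind with a bicyclic saturated group. The expectation for compound 4 in this assay is therefore a shift toward a weaker number, a 6.1-fold higher number from compound 2 to compound 4 (0.78 log units; beyond the scatter), with a real chance that only a limit is returned. Compound 4 is estimated at 20000 nM, within a range of 6000 nM to 60000 nM.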

Compound 4, half-maximal inhibitory concentration: 8800 nM
The estimate for compound 4 lay 2.3-fold (0.36 log units) above the measured number; the range from low to high includes it.
By their numbers in this assay, from the lowest: compound 2; then compounds 4 and 1 (each within the scatter of the next). At a limit, above all of these: compound 3.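

Replacing the anilino group on a sulfonyl sulfur with the saturated group of compound 4, which has 0 hydrogen-bond donors, gives only a modest step in this assay: a 2.7-fold higher number from compound 2 to compound 4 (0.43 log units; beyond the scatter). In this pair, the hydrogen-bond donor of the anilino group is therefore not required for a measured number. Compound 3 also has a saturated nitrogen ring on the sulfonyl sulfur, yet its result is a limit and not a number, so the absence of that donor does not settle the outcome on its own: the limit of > 30000 nM in this assay, at which 1 of the 4 values shown sits.

The compounds shown leave open whether a smaller group on the sulfonyl sulfur, such as dimethylamino or pyrrolidine, would stay near compound 4 or move away from it. They also leave open how an anilino group carrying a carboxylic acid would compare with compound 2.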